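Cytotoxicity of thiocarbamoyl compounds: from compound 3 to compound 4

The source may report more compounds than this note shows. Statements on the series, on what has been measured and on what is new or still open speak of the compounds shown alone.

Measured so far in an ADME assay on Huh-7 cells (Homo sapiens) for cytotoxicity; a higher number here means that more compound is tolerated, a lower number that less compound is tolerated:
Compound 1 `NC(=S)n1ccc2c(OCCCCCOc3ccc(Cl)cc3)cccc21` gives 24700 nM.
Compound 2 `O=C(NC(=S)N1CCc2cc(OCc3ccccc3)ccc21)c1ccccc1` gives 45200 nM.
Compound 3 `COc1ccc(C(=O)NC(=S)N2CCc3c(OCCCCCOc4ccc(Cl)cc4)cccc32)cc1` gives 34400 nM.

Compound 3 stands second highest of the three numbers; its gaps to compound 2 and to compound 1 both lie within the scatter, so the three values cannot be ranked. Compound 4 `O=C(NC(=S)N1CCc2c(OCCCCCOc3ccc(Cl)cc3)cccc21)c1ccno1` differs from compound 3 in one place: 1,2-oxazol-5-yl in place of 4-methoxyphenyl on a carbonyl carbon. Within the data shown here, no step between measured compounds is known that matches this change, so nothing beyond the three values supports a direction. The expectation is a step from compound 3 to compound 4 of a 1.1-fold higher number from compound 3 to compound 4 (0.04 log units; within the scatter), that is, none beyond the scatter. Compound 4 is therefore estimated at 38000 nM, with a range from 15000 nM to 100000 nM.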

Compound 4, half-maximal cytotoxic concentration: 37100 nM
Beside the measured number, compound 4's estimate is 1.0-fold (0.01 log units) above it, within the range that was stated.
By their numbers in this assay, from the lowest: compounds 1, 3, 4 and 2 (each within the scatter of the next).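

In this assay, 1,2-oxazol-5-yl in place of 4-methoxyphenyl on the carbonyl carbon gives a 1.1-fold higher number from compound 3 to compound 4 (0.03 log units; within the scatter), a step within the scatter. Among these compounds, this is the first comparison here between compounds that differ in one place, and it shows that a five-membered aromatic ring with two hetero atoms can stand on this carbonyl carbon with no change beyond the scatter. No evidence at hand bears on this result. Going by these compounds, whether a non-aromatic group on this carbonyl carbon, such as a cyclohexyl ring or a chain carrying an amine or a carboxylic acid, would move the number beyond the scatter remains open.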